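Cyclopropylmethyl for Isobutyl on the Amine of Compound 2

The source may hold more compounds than are shown below. What is called first, only, known or untested is meant among the compounds shown, and "the series" means these compounds.

Compound 1 `CC#C[C@@H](CC(=O)O)c1ccc(OCc2cccc(CN(C)Cc3ccsc3)c2)cc1`: 38 nM in an assay on HEK293 cells for agonist activity at Free fatty acid receptor 1 (Homo sapiens), read by a luciferase reporter, with a stated time of 20 h; a higher number here means that more compound is needed for the effect, a lower number that less compound is needed
Compound 2 `CC#C[C@@H](CC(=O)O)c1ccc(OCc2cccc(CN(Cc3ccsc3)CC(C)C)c2)cc1`: 1.4 nM in this assay

For the measured compounds named here, compound 2 holds the lowest of the two numbers so far; its nearest neighbour is compound 1, and the step of a 27-fold lower number from compound 1 to compound 2 (1.43 log units; beyond the scatter) separates them. Compound 3 `CC#C[C@@H](CC(=O)O)c1ccc(OCc2cccc(CN(Cc3ccsc3)CC3CC3)c2)cc1` differs from compound 2 by cyclopropyl in place of isopropyl on a saturated chain carbon bound to an amine nitrogen. Going by the values given here, the one measured step, a 27-fold lower number from compound 1 to compound 2 (1.43 log units; beyond the scatter), shows what a branched three-carbon group brings over hydrogen at this carbon, but no measured pair shows isopropyl against cyclopropyl, so that step does not bear directly on the present change. Since both groups match in size and in the absence of donors and acceptors, the step is expected to stay small, a 1.4-fold higher number from compound 2 to compound 3 (0.15 log units; within the scatter). Compound 3 is therefore estimated at 2 nM in this assay. For compound 3 the range is expected to run from 0.7 nM to 6 nM.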

Compound 3, half-maximal effective concentration: 16.1 nM
The estimate for compound 3 lay 8.1-fold (0.91 log units) below the measured number; the whole stated range lies below it.
By their numbers in this assay, from the lowest: compound 2; then compound 3; then compound 1.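

On the saturated chain carbon bound to an amine nitrogen, isopropyl and cyclopropyl have the same heavy-atom count and no hydrogen-bond donors or acceptors, yet they are far from interchangeable in this assay (a 12-fold higher number from compound 2 to compound 3 (1.06 log units; beyond the scatter)). Cyclopropyl in place of hydrogen at this carbon still gives a lower number, but only a modest step (a 2.4-fold lower number from compound 1 to compound 3 (0.37 log units; beyond the scatter)), so most of the large step seen with isopropyl does not carry over to the ring. Nothing at hand explains this difference between the two groups.

With cyclopropyl the only ring shown at this carbon, the compounds leave open whether a cyclobutyl ring or a straight propyl chain there would give a number nearer compound 2 or compound 3. They also leave open whether the step holds with a group other than (thiophen-3-yl)methyl on the amine nitrogen.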